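A 2-Fluorophenyl Limit and Its 3-Fluoro-4-Methylphenyl Replacement

The source may hold more compounds than are shown below. What is called first, only, known or untested is meant among the compounds shown, and "the series" means these compounds.

In a functional assay on KB cells (Homo sapiens) for antiproliferative activity, read by sulforhodamine B assay, with a stated time of 3 days (on this read-out higher numbers stand for an effect only at larger amounts of compound and lower numbers for an effect already at smaller amounts), compound 3 `CCC1=C(O)c2c(oc(-c3ccccc3F)cc2=O)C(CC)(CC)C1=O` gives no number, only a limit of > 56.2 uM. Compound 1 `CCOc1ccc(-c2cc(=O)c3c(o2)C(CC)(CC)C(=O)C(CC)=C3O)cc1` also reaches only a limit, > 52.4 uM. Compound 2 `CCC1=C(O)c2c(oc(-c3ccc(F)cc3)cc2=O)C(CC)(CC)C1=O`, by contrast, gives a measured 33 uM.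

Compound 4 `CCC1=C(O)c2c(oc(-c3ccc(C)c(F)c3)cc2=O)C(CC)(CC)C1=O` carries 3-fluoro-4-methylphenyl in place of 2-fluorophenyl on an aromatic carbon. Within the data shown here, two measured steps bear on this change. The closer one is an at least 1.7-fold higher number from compound 2 to compound 3 (0.23 log units; that floor lies within the scatter), which leaves 2-fluorophenyl as the less favourable of the two fluorophenyl groups only as far as that floor can show. The other is an at least 1.5-fold lower number from compound 1 to compound 2 (0.20 log units; that floor lies within the scatter). Neither step establishes a size beyond the scatter, so the expectation is modest. It rests mainly on compound 2 at 33 uM, whose 4-fluorophenyl group is the nearest measured match. Compound 4 could still end as a limit in this assay. The expected step is an at least 1.7-fold lower number from compound 3 to compound 4 (0.24 log units; that floor lies within the scatter). Compound 4 is estimated at 32 uM, with an expected range of 13 uM to 75 uM.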

Compound 4, concentration for half-maximal effect: 28.1 uM
Beside the measured number, compound 4's estimate is 1.1-fold (0.06 log units) above it, and the stated range covers the measured number.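

At this place on the aromatic carbon next to the ring oxygen, 3-fluoro-4-methylphenyl in place of 2-fluorophenyl replaces a limit with a measured number in this assay, and the step reads as an at least 2.0-fold lower number from compound 3 to compound 4 (0.30 log units; that floor lies within the scatter). The comparison with the 4-fluorophenyl group, a 1.2-fold lower number from compound 2 to compound 4 (0.07 log units; within the scatter), does not separate that group from 3-fluoro-4-methylphenyl, so two different substituted phenyl groups now give measured numbers that cannot be told apart. The comparison with the 4-ethoxyphenyl group gives an at least 1.8-fold lower number from compound 1 to compound 4 (0.27 log units; that floor lies within the scatter), which is again only a floor, set by a limit.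

It remains open whether any group at this place can move the number beyond the scatter, as no step shown does so. Also open, as far as these compounds go, is what an amine or a carboxylic acid on the phenyl ring would give.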